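The source may report more compounds than this note shows. Statements on the series, on what has been measured and on what is new or still open speak of the compounds shown alone.

In a functional assay on NCI-H460 cells (Homo sapiens) for inhibition, read by sulforhodamine B assay, with a stated time of 48 h (a higher number here means a weaker inhibitor of growth, a lower number a stronger inhibitor of growth), the measured compounds stand as follows

Compound 1 (`N#CCC1=NN=C(c2ccc(Br)cc2)C(CC(=O)c2ccc(Br)cc2)O1`) gives 22100 nM
Compound 2 (`N#CCC1=NN=C(c2ccc(Br)cc2)C(CC(=O)c2ccc([N+](=O)[O-])cc2)O1`) gives 23000 nM
Compound 3 (`N#CCC1=NN=C(c2ccc([N+](=O)[O-])cc2)C(CC(=O)c2ccc([N+](=O)[O-])cc2)O1`) gives 2600 nM

Compound 3, with 2600 nM as its value, has the lowest number of the three, and its gaps to compound 1 and compound 2 both lie beyond the scatter. The next compound, compound 4 (`N#CCC1=NN=C(c2ccc([N+](=O)[O-])cc2)C(CC(=O)c2ccc(Br)cc2)O1`), departs from compound 3 in one place, with bromo in place of nitro on an aromatic carbon of a six-membered aromatic ring of carbon only, para to a large group (bromo in place of nitro on an aromatic carbon).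

Within the data shown here, two measured steps bear on this change. The more direct one is a 1.0-fold higher number from compound 1 to compound 2 (0.02 log units; within the scatter) and it is the same exchange on the same ring, run in the opposite direction, while the other aromatic ring carries bromo. Among the measured compounds shown here, the second, an 8.8-fold lower number from compound 2 to compound 3 (0.95 log units; beyond the scatter) as its size, is the exchange on that other ring, and it is the only modest step here. As far as these compounds go, compound 3 and compound 4 both carry nitro on that other ring, and no exchange on the changing ring has been measured in that setting, so the upper side stays open.

No step beyond the scatter is therefore expected in this assay, and the expected change is a 1.3-fold higher number from compound 3 to compound 4 (0.13 log units; within the scatter) in estimate. Compound 4 is expected at about 3500 nM (estimated range 1300 nM to 12000 nM).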

Compound 4, concentration for 50% growth inhibition: 40000 nM
Compound 4: middle estimate off by 11-fold (1.06 log units), on the low side; the whole stated range lies below it.
By their numbers in this assay, from the lowest: compound 3; then compounds 1, 2 and 4 (each within the scatter of the next).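

In this assay, the exchange at this position is not silent in every setting: with nitro on the other aromatic ring, bromo in place of nitro gives a 15-fold higher number from compound 3 to compound 4 (1.19 log units; beyond the scatter), so the effect of the change depends on what the other ring carries: the same change on two cores in this assay, a 1.0-fold higher number (0.02 log units; within the scatter) from compound 1 to compound 2 and a 15-fold lower number (1.19 log units; beyond the scatter) from compound 4 to compound 3, 16-fold (1.20 log units) apart, beyond the scatter of two such steps

The dependence also holds in the other direction, since nitro in place of bromo on the other aromatic ring gives a 1.8-fold higher number from compound 1 to compound 4 (0.26 log units; within the scatter) when the changing ring carries bromo, while the same exchange gives a step beyond the scatter when the changing ring carries nitro: the same change on two cores in this assay, an 8.8-fold lower number (0.95 log units; beyond the scatter) from compound 2 to compound 3 and a 1.8-fold higher number (0.26 log units; within the scatter) from compound 1 to compound 4, 16-fold (1.20 log units) apart, beyond the scatter of two such steps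

Compound 2 and compound 4 each carry a single nitro and sit with compound 1, each within the scatter of the next, so among these four compounds only compound 3, with nitro on both rings, stands apart.

The compounds shown leave open whether this gain belongs to nitro itself or would also appear with another group on both rings, such as an amine or a carboxylic acid. They also leave open whether the two rings stay coupled in this way when the nitrile on the shared core gives way to an amide.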